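Swapping the Aryl for Isobutyl on the Ether Oxygen

A few compounds are considered here, and "the series" means these few. Any claim that something is new, unique, unknown or untested is made for them only; others in the source may bear on it.

Measured so far, in a functional assay on RAW264.7 cells (Mus musculus) for inhibition, read by Griess assay, with stated times of 1 h and 24 h; on this read-out higher numbers stand for weaker inhibition and lower numbers for stronger inhibition:
compound 1, `O=C1CC(c2ccccc2O)Oc2ccccc21`: 71300 nM
compound 2, `CC(C)c1ccc(COc2ccccc2C2CC(=O)c3ccccc3O2)cc1`: 27100 nM
compound 3, `CCCCOc1ccccc1C1CC(=O)c2ccccc2O1`: 48700 nM

All three share one core and differ only in what sits on the oxygen on the aromatic ring. Compound 2 gives the lowest number of the three, but its gap to compound 3 is within the scatter; only its gap to compound 1 lies beyond the scatter, so compound 2 can be called separated from compound 1 alone.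

Compound 4, `CC(C)CCOc1ccccc1C1CC(=O)c2ccccc2O1`, has not yet been measured in this assay . It differs from compound 2 in one place: isobutyl in place of 4-isopropylphenyl on a saturated chain carbon bound to an oxygen on an aromatic ring.

Among the compounds with values here, two measured steps bear on this change. Adding butyl to the bare oxygen of compound 1 gave a 1.5-fold lower number from compound 1 to compound 3 (0.17 log units; within the scatter). Going from the 4-isopropylphenyl group of compound 2 to the propyl chain of compound 3 gave a 1.8-fold higher number from compound 2 to compound 3 (0.25 log units; within the scatter). Isobutyl, like butyl, is a short chain of four carbon atoms with no ring, so compound 4 is expected to sit close to compound 3, and the step is estimated as a 1.7-fold higher number from compound 2 to compound 4 (0.22 log units; within the scatter), not beyond the scatter. For compound 4 the estimate in this assay is 45000 nM, with a range from 20000 nM to 95000 nM.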

Compound 4, half-maximal inhibitory concentration: 39200 nM
Compound 4: the middle estimate sits 1.1-fold (0.06 log units) above what was measured; the measured number falls inside the stated range.
By their numbers in this assay, from the lowest: compounds 2, 4, 3 and 1 (each within the scatter of the next, the first and the last beyond it).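

In this assay, the ring-free isobutyl group cannot be told apart from the larger 4-isopropylphenyl group at this place on a saturated chain carbon bound to an oxygen on an aromatic ring: the step is a 1.4-fold higher number from compound 2 to compound 4 (0.16 log units; within the scatter). Adding one methyl to the straight chain also produces no readable change, with a 1.2-fold lower number from compound 3 to compound 4 (0.09 log units; within the scatter), so branching of the chain has no visible effect in this pair, and the step of a 1.8-fold lower number from compound 1 to compound 4 (0.26 log units; within the scatter) shows that compound 4, unlike compound 2, is not separated from the core of compound 1 with its bare oxygen. No measurement here offers an explanation for any of these steps.

On these data alone, it remains open whether a group with an amine or a carboxylic acid on this oxygen, or a chain longer than isopentyl, would move the number beyond the scatter from compound 1. A plain phenyl in place of 4-isopropylphenyl could also show whether the ring alone accounts for the separation of compound 2 from compound 1, or whether its isopropyl group is needed as well.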